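A few compounds are considered here, and "the series" means these few. Any claim that something is new, unique, unknown or untested is made for them only; others in the source may bear on it.

Measured in a functional assay on SU-DHL-6 cells (Homo sapiens) for antiproliferative activity, read by MTT assay; on this read-out higher numbers stand for weaker inhibition and lower numbers for stronger inhibition:
- Compound 1 `COc1ncc(-c2ccc3ncnc(N[C@H]4CCCN(C(=O)C(F)(F)F)C4)c3c2)cc1C#N` gives 210 nM
- Compound 2 `COc1ncc(-c2ccc3ncnc(N[C@H]4CCCN(C(=O)c5cccnc5)C4)c3c2)cc1C#N` gives 120 nM
- Compound 3 `CCOC(=O)CN1CCC[C@H](Nc2ncnc3ccc(-c4cnc(OC)c(C#N)c4)cc23)C1` gives 500 nM

Compound 1 holds the second highest of these three numbers; compound 2 is nearest, within the scatter, and compound 3 furthest. Compound 4 `COc1ncc(-c2ccc3ncnc(N[C@H]4CCCN(C(=O)c5coc([N+](=O)[O-])c5)C4)c3c2)cc1C#N` differs from compound 1 by 5-nitrofuran-3-yl in place of trifluoromethyl on a carbonyl carbon. The step that bears most on this is a 1.8-fold lower number from compound 1 to compound 2 (0.24 log units; within the scatter), where an aromatic ring likewise replaces the trifluoromethyl on the carbonyl carbon. The steps of a 2.4-fold higher number from compound 1 to compound 3 (0.38 log units; beyond the scatter) and a 4.2-fold higher number from compound 2 to compound 3 (0.62 log units; beyond the scatter) alter the ring nitrogen's substituent in another way and speak less directly to this change. Compound 4 is therefore expected to show only a small step, a 1.3-fold lower number from compound 1 to compound 4 (0.12 log units; within the scatter), probably within the scatter. The estimate for compound 4 is 160 nM, ranging from 60 nM to 450 nM.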

Compound 4, half-maximal inhibitory concentration: 140 nM
Compound 4: the middle estimate sits 1.1-fold (0.06 log units) above what was measured, within the range that was stated.
By their numbers in this assay, from the lowest: compounds 2, 4 and 1 (each within the scatter of the next); then compound 3.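

In this assay, a five-membered nitrofuran ring on the carbonyl carbon can't be told apart from the pyridine ring (a 1.2-fold higher number from compound 2 to compound 4 (0.07 log units; within the scatter)) or from trifluoromethyl (a 1.5-fold lower number from compound 1 to compound 4 (0.18 log units; within the scatter)), so this position tolerates all three groups. Replacing the whole (5-nitrofuran-3-yl)carbonyl group with (ethoxycarbonyl)methyl on the amine nitrogen in a ring is a larger change (a 3.6-fold lower number from compound 3 to compound 4 (0.55 log units; beyond the scatter)). Nothing here explains these numbers. Going by these compounds, whether a plain phenyl ring, or a furan carrying an amine or a carboxylic acid in place of the nitro group, would give similar numbers remains open.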